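The source may report more compounds than this note shows. Statements on the series, on what has been measured and on what is new or still open speak of the compounds shown alone.

Compound 1 `Cc1cc(N2CC[C@@H](C)[C@@H](N(C)c3ncnc4[nH]ccc34)C2)n2nc(SCc3ccccc3Br)nc2n1` was tested in a functional assay on BGC-823 cells (Homo sapiens) for inhibition, read by MTT assay, with a stated time of 72 h (on this read-out lower numbers stand for stronger inhibition and higher numbers for weaker inhibition), where compound 1 gives 81100 nM. This is the highest of the two numbers available. For the measured compounds named here, the other measured compound, compound 2 `CCCCCc1c(C)nc2nc(SCc3ccc(Cl)cc3)nn2c1N1CC[C@@H](C)[C@@H](N(C)c2ncnc3[nH]ccc23)C1`, gives 32300 nM in this assay; compound 1 and compound 2 differ in several places at once, so their two values show only that compound 2 sits at a lower number than compound 1.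

Compound 3 `COc1ccc(CSc2nc3nc(C)cc(N4CC[C@@H](C)[C@@H](N(C)c5ncnc6[nH]ccc56)C4)n3n2)cc1` has not been measured. It differs from compound 1 in one place: 4-methoxyphenyl in place of 2-bromophenyl on a saturated chain carbon bound to a sulfur. The shared core and the rest of the molecule are unchanged. Going by the values given here, nothing among the measured compounds isolates this change, so its effect cannot be read from a step already made. A small step is expected, possibly toward a lower number, and the estimated step of a 1.6-fold lower number from compound 1 to compound 3 (0.21 log units; within the scatter) stays close to the scatter. Compound 3 is therefore estimated at 50000 nM in this assay, with a range from 20000 nM to 130000 nM.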

Compound 3, half-maximal inhibitory concentration: 69900 nM
Compound 3: the middle estimate sits 1.4-fold (0.15 log units) below what was measured; measured number inside the range.
By their numbers in this assay, from the lowest: compound 2; then compounds 3 and 1 (each within the scatter of the next).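

In this assay the exchange of 2-bromophenyl for 4-methoxyphenyl on a saturated chain carbon bound to a sulfur gives a 1.2-fold lower number from compound 1 to compound 3 (0.06 log units; within the scatter) and so stays within the scatter. For the compounds shown here, this is the one step here that isolates this position, and it shows that these two aryl groups cannot be told apart in this read-out, even though the entering group counts one hydrogen-bond acceptor and the leaving group none. Nothing available offers a reason for this outcome.

The compounds shown leave open whether a phenyl ring carrying an amine or a carboxylic acid, or a plain longer chain in place of the ring, would move the number beyond the scatter at this place. They also leave open whether the same exchange would behave alike on the core of compound 2.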